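This account rests on a few compounds, and the source may have more. Where it says the series, first, only, none or still open, it means among the compounds named here.

For the measured compounds named here, compound 3 `CC1=C(C(=O)OCC2CC2)C(c2ccco2)NC(=O)N1` gives 138 nM in an assay on membranes from HEK293 cells for displacement of a labelled ligand from adenosine receptor A2b (Homo sapiens), read by scintillation counting, with a stated time of 30 min (a higher number here means a weaker inhibitor, a lower number a stronger inhibitor), and stands lowest of the three numbers measured so far. Going by the values given here, compound 1 `CCCOC(=O)C1=C(C)NC(=O)NC1c1ccoc1` gives 1190 nM in this assay and compound 2 `CC1=C(C(=O)OCc2ccccc2)C(c2ccoc2)NC(=O)N1` gives 6650 nM; the only single-point step among them, a 5.6-fold higher number from compound 1 to compound 2 (0.75 log units; beyond the scatter), concerns the ester and not the ring on the saturated ring carbon. Compound 4 `CC1=C(C(=O)OCC2CC2)C(c2ccoc2)NC(=O)N1` is formed from compound 3 by furan-3-yl in place of furan-2-yl on a saturated ring carbon. Among the compounds with values here, no measured step isolates this change: compound 1 and compound 2 carry furan-3-yl but also differ from compound 3 in the ester, so their values alone do not settle it. A modest step toward a higher number, direction uncertain, is expected, estimated as a 2.9-fold higher number from compound 3 to compound 4 (0.46 log units; beyond the scatter). Compound 4 is expected at 400 nM, within 120 nM to 1400 nM.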

Compound 4, inhibition constant: 426 nM
Compound 4: the middle estimate sits 1.1-fold (0.03 log units) below what was measured, and the stated range covers the measured number.
By their numbers in this assay, from the lowest: compound 3; then compound 4; then compound 1; then compound 2.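

In this assay, the furan swap can now be read alone, with the ester held constant: furan-3-yl in place of furan-2-yl on a saturated ring carbon gives a 3.1-fold higher number from compound 3 to compound 4 (0.49 log units; beyond the scatter). With furan-3-yl fixed, cyclopropyl in the ester gives a 16-fold lower number from compound 2 to compound 4 (1.19 log units; beyond the scatter) and a 2.8-fold lower number from compound 1 to compound 4 (0.45 log units; beyond the scatter), so the ester also moves the number when the ring stays the same. No evidence on hand accounts for either change.

Going by these compounds, whether the furan step has the same direction and size with the ethyl or phenyl esters remains open. So does how a thiophen-2-yl or a plain phenyl ring would compare at this saturated ring carbon.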